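The compounds below may be only part of what the source reports. "The series", "measured", "known", "first", "only" and "open" are said of these compounds alone.

Measured in an ADME assay on the whole organism for metabolic stability, with Rattus norvegicus as the target; a lower number here means that the compound disappears faster, a higher number that the compound lasts longer:
- Compound 1 `O=C(Nc1cccnc1-c1ccsc1)N1CCN2C(=O)N([C@H]3C[C@@H]3c3ccccc3)C(=O)[C@@H]2C1`: 10 h
- Compound 2 `N#Cc1cc(Cl)c(NC(=O)N2CCN3C(=O)N([C@H]4C[C@@H]4c4ccccc4)C(=O)[C@@H]3C2)c(Cl)c1`: 5.4 h

Compound 2, at 5.4 h, stands within the scatter of compound 1, so the two values cannot be separated. Compound 3 `O=C(Nc1cccc(Cl)c1Cl)N1CCN2C(=O)N([C@H]3C[C@@H]3c3ccccc3)C(=O)[C@@H]2C1` carries 2,3-dichlorophenyl in place of 2,6-dichloro-4-cyanophenyl on an amide-type nitrogen.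

For the measured compounds named here, only one measured step bears on this place, a 1.9-fold lower number from compound 1 to compound 2 (0.27 log units; within the scatter). It exchanges a different group on the same amide-type nitrogen and stays within the scatter. Going by the values given here, a single step gives no trend, and no measured step isolates the loss of the nitrile or the new chlorine arrangement. On that basis, no change beyond the scatter is expected in this assay. The expected step is a 1.1-fold higher number from compound 2 to compound 3 (0.05 log units; within the scatter), with no firm direction. For compound 3 the estimated half-life is 6 h, with an expected range of 2.5 h to 13 h.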

Compound 3, half-life: 2.2 h
Beside the measured number, compound 3's estimate is 2.7-fold (0.44 log units) above it; the measured number lies below the stated range.
By their numbers in this assay, from the lowest: compound 3; then compounds 2 and 1 (each within the scatter of the next).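

In this assay, the group on the amide-type nitrogen now gives changes beyond the scatter: a 2.5-fold lower number from compound 2 to compound 3 (0.39 log units; beyond the scatter) with 2,3-dichlorophenyl in place of 2,6-dichloro-4-cyanophenyl, and a 4.5-fold lower number from compound 1 to compound 3 (0.66 log units; beyond the scatter) with 2,3-dichlorophenyl in place of 2-(thiophen-3-yl)pyridin-3-yl. This place therefore affects half-life on the shared core, which the earlier step, within the scatter, could not show, and compound 3 is the lowest of the three, though both of its steps are modest. Nothing available accounts for these differences.

The step to compound 3 removes the nitrile and rearranges the chlorines in one move, so the share of each remains unresolved. Going by these compounds, how a carboxylic acid or a methoxy group on the phenyl ring would read here also remains open.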